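The source may hold more compounds than are shown below. What is called first, only, known or untested is meant among the compounds shown, and "the series" means these compounds.

Measured compounds:
- compound 1, `O=C(NCC[C@@H](NS(=O)(=O)c1ccc(OCc2cc(Br)cc(Br)c2)cc1)C(=O)NO)OCc1ccccc1`, in an assay on isolated protein for inhibition of matrix metalloproteinase-9 (Homo sapiens), read by fluorescence, with stated times of 4 h, 15 s and 20 min (on this read-out lower numbers stand for stronger inhibition and higher numbers for weaker inhibition), gives 11000 nM
- compound 2, `O=C(CNS(=O)(=O)c1ccc(OCc2ccc(OC(F)(F)F)cc2)cc1)NO`, in this assay gives 37 nM

Of these two numbers, compound 2 has the lower one; compound 1 sits a long way higher, a gap far beyond the usual scatter of this kind of measurement. Compound 3, `O=C(CNS(=O)(=O)c1ccc(OCc2ccc(Br)cc2)cc1)NO`, has not been measured in this assay yet. It keeps the whole of compound 2 apart from one change: bromo in place of trifluoromethoxy on an aromatic carbon, para to a large group. No pair of measured compounds shows this change directly, so the direction of the step cannot be read off from a shown step. With only a single heavy atom swapped for a small group at the far end of the molecule, the expectation is a step from compound 2 to compound 3 of a 1.2-fold lower number from compound 2 to compound 3 (0.09 log units; within the scatter), which is within the scatter, with no clear direction. Compound 3 is therefore estimated in this assay at 30 nM, with a plausible range from 8 nM to 120 nM.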

Compound 3, half-maximal inhibitory concentration: 1.4 nM
Estimate against measurement, compound 3: 21-fold (1.33 log units) above; measured number below the stated range.
By their numbers in this assay, from the lowest: compound 3; then compound 2; then compound 1.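

In this assay, for the compounds shown here, putting bromo in place of trifluoromethoxy on an aromatic carbon, para to a large group, gives a 26-fold lower number from compound 2 to compound 3 (1.42 log units; beyond the scatter), the first step in this set that can be read from a change in one place. It shows that this far end of the molecule is not a place where one group can stand in for another without consequence, even though the rest of the structure stays the same. The entering group has fewer heavy atoms and no hydrogen-bond acceptor, but no measurement shown here connects either difference with the size of the step.

Going by these compounds, whether a chloro, a methoxy or an amine at this same place would give a number closer to that of compound 2 or of compound 3 remains open, so a single pair cannot yet show a trend across groups. Also open, on these data alone, is whether the same swap would have a similar effect on a different core, such as that of compound 1, which differs from compound 2 in more than one place.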